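A few compounds are considered here, and "the series" means these few. Any claim that something is new, unique, unknown or untested is made for them only; others in the source may bear on it.

In a functional assay on A-431 cells (Homo sapiens) for antiproliferative activity, read by CCK-8 assay, with a stated time of 72 h (on this read-out higher numbers stand for weaker inhibition and lower numbers for stronger inhibition), compound 1 `COc1cccc(Nc2nc(Nc3cc(C)[nH]n3)cc(N3CCN(C)CC3)n2)c1` gives 332 nM, compound 2 `Cc1cc(Nc2cc(N3CCN(C)CC3)nc(Nc3cccc([N+](=O)[O-])c3)n2)n[nH]1` gives 166 nM and compound 3 `Cc1cc(Nc2cc(N3CCN(C)CC3)nc(Nc3cccc(Cl)c3)n2)n[nH]1` gives 87.5 nM. Two steps fix the place of the chloro compound at the low end of this small set: a 3.8-fold lower number from compound 1 to compound 3 (0.58 log units; beyond the scatter), and a 1.9-fold lower number from compound 2 to compound 3 (0.28 log units; within the scatter). Compound 4 `Cc1cc(Nc2cc(N3CCN(C)CC3)nc(Nc3ccc(C#N)cc3)n2)n[nH]1` has 4-cyanophenyl in place of 3-chlorophenyl on a nitrogen on an aromatic ring. Among the measured compounds shown here, the only steps that bear on this are swaps on that same ring, the third being a 2.0-fold lower number from compound 1 to compound 2 (0.30 log units; within the scatter). For the measured compounds named here, no measured compound carries a nitrile, so none tests this change directly. Those steps are small, so only a small move toward higher numbers is expected. The expected step is a 1.8-fold higher number from compound 3 to compound 4 (0.26 log units; within the scatter). Compound 4 is estimated at 160 nM, with a range of 60 nM to 450 nM.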

Compound 4, half-maximal inhibitory concentration: 140 nM
Compound 4: middle estimate off by 1.1-fold (0.06 log units), on the high side, within the range that was stated.
By their numbers in this assay, from the lowest: compounds 3, 4, 2 and 1 (each within the scatter of the next, the first and the last beyond it).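

In this assay, a nitrile-bearing aryl group on this nitrogen stays level with the chloro and nitro groups: 4-cyanophenyl in place of 3-chlorophenyl gives a step within the scatter (a 1.6-fold higher number from compound 3 to compound 4 (0.20 log units; within the scatter)), as does 4-cyanophenyl in place of 3-nitrophenyl (a 1.2-fold lower number from compound 2 to compound 4 (0.07 log units; within the scatter)). Only the methoxy compound separates, and modestly (a 2.4-fold lower number from compound 1 to compound 4 (0.38 log units; beyond the scatter)). Nothing measured here accounts for these steps.

As far as these compounds go, in this change the substituent and its ring position differ together, so the effect of each stays open. 3-cyanophenyl and 4-chlorophenyl would separate them, and 4-aminophenyl would extend the range of groups.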